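Bromo for cyano on the amide aryl: toxicity outlook

The source may hold more compounds than are shown below. What is called first, only, known or untested is meant among the compounds shown, and "the series" means these compounds.

Three amides on the shared core have been run in a toxicity assay on THP-1 cells (Homo sapiens) for inhibition; on this read-out higher numbers stand for lower toxicity in this test and lower numbers for higher toxicity in this test. Compound 1, `COc1ccc(-c2cnc(NC(=O)c3cccnc3)n2C)cc1`, carries pyridin-3-yl on the carbonyl carbon; in this assay compound 1 reaches only a limit, > 100000 nM. Compound 2, `CCC(=O)Nc1ncc(-c2ccc(OC)cc2)n1C`, has ethyl in that place and in this assay compound 2 also stops at a limit, > 100000 nM. Compound 3, `COc1ccc(-c2cnc(NC(=O)c3cccc(C#N)c3)n2C)cc1`, with 3-cyanophenyl on the carbonyl carbon, gives in this assay a limit as well, > 100000 nM. The steps among them are therefore a step that the two limits leave unreadable from compound 1 to compound 2, a step that the two limits leave unreadable from compound 1 to compound 3 and a step that the two limits leave unreadable from compound 2 to compound 3, all unreadable because every value sits at the limit of > 100000 nM in this assay, at which 3 of the 3 values shown sit. Compound 3 thus stands where the whole set stands: at the upper limit, with no toxicity detected.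

Compound 4, `COc1ccc(-c2cnc(NC(=O)c3cccc(Br)c3)n2C)cc1`, differs from compound 3 by bromo in place of cyano on an aromatic carbon. Among the compounds with values here, no measured step bears on this change, and nothing in the three limits points to toxicity appearing. The expected step is a step that the limit leaves unreadable from compound 3 to compound 4, none beyond the scatter. Compound 4 is therefore estimated at 150000 nM, within 50000 nM to 500000 nM, most likely reported again as a limit.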

Compound 4, half-maximal cytotoxic concentration: > 100000 nM
Compound 4: a limit, no number; the forecaster's own chance of this, stated with the estimate: 80%; the middle value lies beyond the limit too.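

No step to compound 4 from compound 1, compound 2 or compound 3 can be read in this assay, since all four compounds give only a limit: the limit of > 100000 nM in this assay, at which 4 of the 4 values shown sit.

The compounds shown leave open at what concentration any of them would register in this assay, and whether their amide groups differ there at all.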